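A few compounds are considered here, and "the series" means these few. Any claim that something is new, unique, unknown or untested is made for them only; others in the source may bear on it.

Measured compounds:

- compound 1, `CC(C)c1c(C(=O)NCC2CCCCC2)nn(-c2ccc(F)cc2)c1OC[C@@H](O)C[C@@H](O)CC(=O)O`: 17 nM
- compound 2, `Cc1ccc(CNC(=O)c2nn(-c3ccc(F)cc3)c(OC[C@@H](O)C[C@@H](O)CC(=O)O)c2C(C)C)cc1`: 15 nM
- compound 3, `COCc1cccc(CNC(=O)c2nn(-c3ccc(F)cc3)c(OC[C@@H](O)C[C@@H](O)CC(=O)O)c2C(C)C)c1`: 31 nM

All three were tested in an assay on microsomes from liver for inhibition of 3-hydroxy-3-methylglutaryl-coenzyme A reductase (Rattus norvegicus); on this read-out higher numbers stand for weaker inhibition and lower numbers for stronger inhibition. Compound 3 gives the highest of the three numbers: against compound 1 the gap, a 1.8-fold higher number from compound 1 to compound 3 (0.26 log units; within the scatter), is within the scatter, while against compound 2 the gap, a 2.1-fold higher number from compound 2 to compound 3 (0.32 log units; beyond the scatter), is a modest step beyond it. So compound 3 is, at most, a slightly weaker inhibitor than compound 2 and indistinguishable from compound 1.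

Compound 4, `COc1cccc(CN(C)C(=O)c2nn(-c3ccc(F)cc3)c(OC[C@@H](O)C[C@@H](O)CC(=O)O)c2C(C)C)c1`, has not yet been measured in this assay. It differs from compound 3 by (3-methoxybenzyl)(methyl)amino in place of (3-(methoxymethyl)benzyl)amino on a carbonyl carbon. The three measured steps all vary the group on the saturated chain carbon bound to the amide-type nitrogen, and all were small: a 1.1-fold lower number from compound 1 to compound 2 (0.05 log units; within the scatter) and a 1.8-fold higher number from compound 1 to compound 3 (0.26 log units; within the scatter) within the scatter, a 2.1-fold higher number from compound 2 to compound 3 (0.32 log units; beyond the scatter) just beyond. They therefore suggest the aromatic part tolerates changes without large shifts. As far as these compounds go, none of them, however, replaces the hydrogen-bond donor on the nitrogen with a methyl, so that part of the change is untested. The expectation for compound 4 is a small step, if any, and more likely toward a higher number, a 1.5-fold higher number from compound 3 to compound 4 (0.16 log units; within the scatter). Compound 4 is thus estimated at 45 nM, with a range from 15 nM to 150 nM.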

Compound 4, half-maximal inhibitory concentration: 21 nM
Compound 4: middle estimate off by 2.1-fold (0.33 log units), on the high side, and the stated range covers the measured number.
By their numbers in this assay, from the lowest: compounds 2, 1, 4 and 3 (each within the scatter of the next, the first and the last beyond it).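

Among the compounds shown here, compound 4 is the first compound here without the amide hydrogen, carrying a methyl on that nitrogen instead, and in this assay the change leaves no readable mark: the steps, a 1.5-fold lower number from compound 3 to compound 4 (0.17 log units; within the scatter) and a 1.4-fold higher number from compound 2 to compound 4 (0.15 log units; within the scatter) and also a 1.2-fold higher number from compound 1 to compound 4 (0.09 log units; within the scatter) all lie within the scatter. For the compounds shown here, the earlier compounds all kept that hydrogen, so this is the first sign that, with this 3-methoxybenzyl group on the carbonyl carbon, inhibition in this range does not depend on a hydrogen-bond donor at the nitrogen. No measurement is available here that would explain this result.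

The step from compound 3 to compound 4 also exchanges 3-(methoxymethyl) for 3-methoxy on the aromatic ring, so the (3-methoxybenzyl)amino group, which keeps the amide hydrogen, would be needed to separate the effect of the added methyl from that of the ring change. As far as these compounds go, it also remains open whether the nitrogen accepts anything larger than methyl, such as an ethyl group or a longer chain, and whether the same holds with the cyclohexylmethyl or 4-methylbenzyl groups in place of the 3-methoxybenzyl group.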